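The compounds below may be only part of what the source reports. "The series", "measured", "known", "first", "only" and "open" are said of these compounds alone.

Three compounds have been measured in a functional assay on MCF7 cells (Homo sapiens) for inhibition, read by MTT assay, with a stated time of 2 days; a higher number here means a weaker inhibitor, a lower number a stronger inhibitor:
compound 1 `Nc1cccc(/C=C/c2ccccc2O)c1`, 24.7 ug/mL;
compound 2 `COc1cccc(/C=C/c2ccccc2O)c1`, 18 ug/mL;
compound 3 `Nc1cccc(/C=C/c2ccc(O)cc2)c1`, 6 ug/mL.

Compound 1 and compound 2 share one core and differ in a single place: methoxy in place of amino on an aromatic carbon. In this assay this change gives a 1.4-fold lower number from compound 1 to compound 2 (0.14 log units; within the scatter), so the two numbers are not separated by the measurement. Compound 3 carries the same amino group as compound 1 but on a different core; the difference between the two cores is not broken down here. In this assay compound 3 stands lowest of the three numbers, and its distance from compound 1 and from compound 2 lies beyond the scatter in both cases.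

Compound 4 `COc1cccc(/C=C/c2ccc(O)cc2)c1` has not yet been measured. It stands to compound 3 as compound 2 stands to compound 1: methoxy in place of amino on an aromatic carbon. The place of the change reads the same in both pairs, so it is the same change, seen only once so far among the measured compounds. Because that single earlier instance gave a 1.4-fold lower number from compound 1 to compound 2 (0.14 log units; within the scatter), a step within the scatter, the step expected for compound 4 is a 1.3-fold lower number from compound 3 to compound 4 (0.12 log units; within the scatter). This expectation rests on one pair alone and on the assumption that the change behaves alike on the core of compound 3. The estimate for compound 4 in this assay is 4.5 ug/mL, with a range from 2.2 ug/mL to 9 ug/mL.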

Compound 4, half-maximal inhibitory concentration: 21 ug/mL
Beside the measured number, compound 4's estimate is 4.7-fold (0.67 log units) below it, and the stated range ends below it.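

In this assay, methoxy in place of amino on an aromatic carbon gives a 3.5-fold higher number from compound 3 to compound 4 (0.54 log units; beyond the scatter) and so does not repeat the step seen on the other core; in this series the change cannot be carried from one core to the other as a fixed step: the same change on two cores in this assay, a 1.4-fold lower number (0.14 log units; within the scatter) from compound 1 to compound 2 and a 3.5-fold higher number (0.54 log units; beyond the scatter) from compound 3 to compound 4, 4.8-fold (0.68 log units) apart, beyond the scatter of two such steps.
For these two pairs, then, the outcome of the change depends on the core it sits on, and the amino group goes with the lower number only on the core of compound 3, while on the core of compound 1 the measurement does not separate the two groups. The result rests on just two pairs, however, and it does not show why the steps differ or how the change would behave on any further core.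

The compounds shown leave open whether another group in the same place, such as ethoxy, an acetamide or a carboxylic acid, would follow the pattern of one core or of the other. They also leave open which feature of the difference between the two cores goes with the gap between the steps, and whether that gap would appear on other cells.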